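The source may report more compounds than this note shows. Statements on the series, on what has been measured and on what is new or still open speak of the compounds shown alone.

Compound 1 `COc1ccc(/C=N/NC(=O)Nc2ccc(Oc3ccnc(-c4nncn4CCN(C)C)c3)c(F)c2)c(OC)c1` is one of three analogues that share a core and differ only in the aryl group on a carbon with a double bond to nitrogen. In a functional assay on A549 cells (Homo sapiens) for cytotoxicity, read by MTT assay, with a stated time of 72 h (on this read-out lower numbers stand for stronger inhibition and higher numbers for weaker inhibition), compound 1 gives 2820 nM, the second highest of the three numbers. Compound 2 `CN(C)CCn1cnnc1-c1cc(Oc2ccc(NC(=O)N/N=C/c3cccc(Br)c3)cc2F)ccn1` gives 970 nM, a step of a 2.9-fold lower number from compound 1 to compound 2 (0.46 log units; beyond the scatter), while compound 3 `CN(C)CCn1cnnc1-c1cc(Oc2ccc(NC(=O)N/N=C/c3ccc(O)cc3)cc2F)ccn1` gives 3560 nM, a step of a 1.3-fold higher number from compound 1 to compound 3 (0.10 log units; within the scatter). Compound 4 `COc1ccc(/C=N/NC(=O)Nc2ccc(Oc3ccnc(-c4nncn4CCN(C)C)c3)c(F)c2)cc1O` carries the change (3-hydroxy-4-methoxyphenyl in place of 2,4-dimethoxyphenyl on a carbon with a double bond to nitrogen). Among the compounds with values here, the step from compound 1 to compound 3 bears most directly on it, since it also exchanges methoxy for hydroxyl, and stayed within the scatter; the only step beyond the scatter, a 3.7-fold higher number from compound 2 to compound 3 (0.56 log units; beyond the scatter), concerns the bromide. Compound 4 is therefore expected to sit close to compound 1, a step of a 1.1-fold higher number from compound 1 to compound 4 (0.05 log units; within the scatter), with an estimate of 3200 nM and a range of 1400 nM to 7500 nM.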

Compound 4, half-maximal inhibitory concentration: > 100000 nM
Compound 4 was reported as a limit (the forecaster's own chance of this, stated with the estimate: 5%); middle value at least 31-fold (1.49 log units) from the limit.
By their numbers in this assay, from the lowest: compound 2; then compounds 1 and 3 (each within the scatter of the next). At a limit, above all of these: compound 4.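

In this assay compound 4 is reported only as a limit, not as a number: the limit of > 100000 nM in this assay, at which 1 of the 4 values shown sits. Until now, exchanging the aryl group on a carbon with a double bond to nitrogen had produced only modest steps, whereas the 3-hydroxy-4-methoxyphenyl group gives an at least 35-fold higher number from compound 1 to compound 4 (1.54 log units; beyond the scatter), an at least 28-fold higher number from compound 3 to compound 4 (1.44 log units; beyond the scatter) and an at least 100-fold higher number from compound 2 to compound 4 (2.01 log units; beyond the scatter). A hydroxyl alone does not separate compound 4 from the rest, as compound 3 also carries one and gives 3560 nM. The compounds shown leave open whether this large step belongs to the hydroxyl and methoxy pairing as a whole, and whether an amine in place of that hydroxyl would give a number like those of compound 1 and compound 3.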